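The compounds below may be only part of what the source reports. "The series", "measured", "known", "first", "only" and "open" are said of these compounds alone.

Compounds measured in a functional assay on HFL1 cells for antagonist activity at sphingosine 1-phosphate receptor 2 (Homo sapiens), read by ELISA, with a stated time of 24 h, in the presence of a further agent that is not named here; a higher number here means a weaker inhibitor, a lower number a stronger inhibitor:

compound 1, `COC(C(=O)O)c1nn(Cc2cn3cc(OCC4CC4)c(Cl)cc3n2)c2ccccc2c1=O`, 217 nM
compound 2, `C[C@H](C(=O)O)n1nc(Cn2cc3cc(OCC4CC4)c(Cl)cc3n2)c2ccccc2c1=O`, 197 nM

Compound 1 stands at the upper end of these two numbers, yet its gap to compound 2 lies within the usual scatter of this assay, so the two cannot be told apart. Compound 3, `CCC(C(=O)O)c1nn(Cc2cn3cc(OCC4CC4)c(Cl)cc3n2)c2ccccc2c1=O`, has not yet been measured in this assay. It differs from compound 1 in one place: ethyl in place of methoxy on a saturated chain carbon bound to an aromatic carbon and a carbonyl carbon, which leaves the acid and the shared core of compound 1 untouched. Among the measured compounds shown here, no measured pair here makes the same change, so there is no direct guide to its size. Compound 3 is expected to stay close to compound 1, with a step from a 1.1-fold lower number from compound 1 to compound 3 (0.04 log units; within the scatter) that is not expected to reach beyond the scatter in either direction. Compound 3 is therefore estimated at 200 nM, within a range of 70 nM to 600 nM.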

Compound 3, half-maximal inhibitory concentration: 25 nM
The estimate for compound 3 lay 8.0-fold (0.90 log units) above the measured number; the whole stated range lies above it.
By their numbers in this assay, from the lowest: compound 3; then compounds 2 and 1 (each within the scatter of the next).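

In this assay, the saturated chain carbon bound to an aromatic carbon and a carbonyl carbon proves sensitive to what it carries: with the acid and the shared core of compound 1 unchanged, ethyl in place of methoxy gives an 8.7-fold lower number from compound 1 to compound 3 (0.94 log units; beyond the scatter) and is a step beyond the scatter. Among the compounds shown here, this is the first step that can be read at this position, and it shows that a swap of just two heavy atoms, which removes the hydrogen-bond acceptor of methoxy, can move the number markedly. Nothing measured here bears on why the step arises.

This single pair cannot separate the loss of the oxygen from the gain of the carbon. Going by these compounds, how a methyl, a hydroxy group or a longer chain such as propyl would read on this same carbon remains open.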